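From cyclopropyl to cyclobutyl on an amide nitrogen

The source may report more compounds than this note shows. Statements on the series, on what has been measured and on what is new or still open speak of the compounds shown alone.

Of the compounds shown here, two with a shared core have been measured so far in a functional assay on HCT-116 cells (Homo sapiens) for antiproliferative activity, read by sulforhodamine B assay, with a stated time of 72 h (on this read-out higher numbers stand for weaker inhibition and lower numbers for stronger inhibition), and they lie fairly close together. Among the measured compounds shown here, there compound 1 `CN(C)CC[C@@H]1C[C@@H](c2ccc(Cl)c(Cl)c2)[C@H](NC(=O)c2cc(-c3c(Cl)cnn3C)c(Cl)o2)CN1` gives 1710 nM while compound 2 `Cn1ncc(Cl)c1-c1cc(C(=O)N[C@@H]2CN[C@H](CC(=O)NC3CC3)C[C@H]2c2ccc(Cl)c(Cl)c2)oc1Cl` gives 740 nM as the lowest number so far, which makes it the stronger inhibitor of the pair. The next structure, compound 3 `Cn1ncc(Cl)c1-c1cc(C(=O)N[C@@H]2CN[C@H](CC(=O)NC3CCC3)C[C@H]2c2ccc(Cl)c(Cl)c2)oc1Cl`, differs from compound 2 in one place only, with cyclobutyl in place of cyclopropyl on an amide-type nitrogen on an amide-type nitrogen, so that cyclobutyl stands in place of cyclopropyl.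

For the measured compounds named here, only one measured step bears on this change, and only loosely. The modest 2.3-fold lower number from compound 1 to compound 2 (0.36 log units; beyond the scatter) came with cyclopropylcarbamoyl in place of (dimethylamino)methyl and lies just beyond the scatter. Going by the values given here, no measured pair shows what happens when the cyclopropyl ring itself is swapped, so the data give no direction for this smaller edit. The expected outcome is a 1.1-fold lower number from compound 2 to compound 3 (0.02 log units; within the scatter) and so no clear shift either way. For compound 3 the estimated value is 700 nM with an expected range from 300 nM to 1600 nM in this assay overall.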

Compound 3, half-maximal inhibitory concentration: 430 nM
The estimate for compound 3 lay 1.6-fold (0.21 log units) above the measured number; the range from low to high includes it.
By their numbers in this assay, from the lowest: compounds 3 and 2 (each within the scatter of the next); then compound 1.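

In this assay the swap of cyclopropyl for cyclobutyl on the amide-type nitrogen gives a 1.7-fold lower number from compound 2 to compound 3 (0.24 log units; within the scatter) and stays inside the usual scatter, so this position takes the larger ring without a clear change in the number. Replacing (dimethylamino)methyl with cyclobutylcarbamoyl gives a 4.0-fold lower number from compound 1 to compound 3 (0.60 log units; beyond the scatter) on the same chain, a step that lies beyond the scatter, as did the earlier step to cyclopropylcarbamoyl, so two different rings on this amide now stand apart from compound 1. No measurement at hand offers an explanation for these numbers.

The compounds shown leave open whether a still larger ring such as cyclopentyl, or an open chain such as isopropyl, on this nitrogen would carry the number beyond the scatter from compound 2. They also leave open what a ring bearing a hydroxyl group or an amine would do at this place, since both groups tested here hold carbon alone.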